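Para-substituent swap on the arylsulfonyl ring: fluoro to bromo

This account rests on a few compounds, and the source may have more. Where it says the series, first, only, none or still open, it means among the compounds named here.

The measured compounds:
compound 1, `Cc1ccc(S(=O)(=O)N2C/C(=C\c3cccc(F)c3)C(=O)/C(=C/c3cccc(F)c3)C2)cc1`, 18100 nM
compound 2, `O=C1/C(=C/c2cccc(F)c2)CN(S(=O)(=O)c2ccc(O[N+](=O)[O-])cc2)C/C1=C\c1cccc(F)c1`, 15300 nM
compound 3, `O=C1/C(=C/c2cccc(F)c2)CN(S(=O)(=O)c2ccc(F)cc2)C/C1=C\c1cccc(F)c1`, 13500 nM

All three were tested in a functional assay on SMMC-7721 cells (Homo sapiens) for cytotoxicity, read by MTT assay, with a stated time of 24 h; a lower number here means a stronger inhibitor, a higher number a weaker inhibitor. Compound 3 gives the lowest of the three numbers, but its neighbours sit close: compound 2 is a step of a 1.1-fold lower number from compound 2 to compound 3 (0.05 log units; within the scatter) away and compound 1 a step of a 1.3-fold lower number from compound 1 to compound 3 (0.13 log units; within the scatter) away, so none of the three can be set apart from the others.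

Compound 4, `O=C1/C(=C/c2cccc(F)c2)CN(S(=O)(=O)c2ccc(Br)cc2)C/C1=C\c1cccc(F)c1`, is not yet measured. Relative to compound 3 the change is bromo in place of fluoro on an aromatic carbon.

Going by the values given here, every measured step so far is a swap of the group on the same aromatic carbon of the arylsulfonyl ring: from compound 1 to compound 2 the step was a 1.2-fold lower number from compound 1 to compound 2 (0.07 log units; within the scatter), from compound 1 to compound 3 it was a 1.3-fold lower number from compound 1 to compound 3 (0.13 log units; within the scatter), and from compound 2 to compound 3 it was a 1.1-fold lower number from compound 2 to compound 3 (0.05 log units; within the scatter). Methyl, nitrooxy and fluoro at that position gave numbers that are indistinguishable within the scatter. The bromo of compound 4 is a further single-atom change at the same place, so no step beyond the scatter is expected in this assay, in either direction.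

Compound 4 is therefore expected to give 14000 nM, with a range of 7000 nM to 28000 nM. The expected step from compound 3 to compound 4 is a 1.0-fold higher number from compound 3 to compound 4 (0.02 log units; within the scatter).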

Compound 4, half-maximal inhibitory concentration: 11700 nM
Compound 4: the middle estimate sits 1.2-fold (0.08 log units) above what was measured, and the stated range covers the measured number.
By their numbers in this assay, from the lowest: compounds 4, 3, 2 and 1 (each within the scatter of the next).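

With bromo in place of fluoro the result is a 1.2-fold lower number from compound 3 to compound 4 (0.06 log units; within the scatter) and with bromo in place of nitrooxy it is a 1.3-fold lower number from compound 2 to compound 4 (0.12 log units; within the scatter) while bromo in place of methyl gives a 1.5-fold lower number from compound 1 to compound 4 (0.19 log units; within the scatter) so even the largest step yet seen at this aromatic carbon stays within the scatter. The position has now carried two halogens as well as methyl and nitrooxy, and all four compounds remain inseparable in this assay so the flat picture the first three compounds suggested now extends to a fourth group on the arylsulfonyl ring. No measurement available here offers an explanation for this flat picture.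

The compounds shown leave open whether a group of another kind at this carbon, such as an amine, a carboxylic acid or a longer alkyl chain, would produce a step beyond the scatter. They also leave open how much a change elsewhere would matter, since the shared core and its two fluorinated aromatic rings stay the same in all four compounds.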